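Chloro to Methyl: Expecting Little Change for Compound 4

The source may report more compounds than this note shows. Statements on the series, on what has been measured and on what is new or still open speak of the compounds shown alone.

Three compounds have been measured so far:
compound 1, `CCOc1ccc(Br)cc1C(C)NC(=O)N(C)S(=O)(=O)c1ccc(Cl)cc1`, 55700 nM
compound 2, `Cc1ccc(OCc2ccccc2)c(C(C)NC(=O)NS(=O)(=O)c2ccc(Cl)cc2)c1`, 65300 nM
compound 3, `CCOc1ccc(F)cc1C(C)NC(=O)N(C)S(=O)(=O)c1ccccc1`, 11500 nM

These numbers come from a functional assay on thoracic aorta (Rattus norvegicus, strain Wistar), with a stated time of 15 min; on this read-out lower numbers stand for an effect already at smaller amounts and higher numbers for an effect only at larger amounts of compound. Compound 1 stands second highest of the three. Compound 2 lies nearest to it, and the gap between the two is within the usual scatter, so nothing separates them. Compound 3 gives the lowest number, and its gap from compound 1 is beyond the scatter.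

Compound 4, `CCOc1ccc(Br)cc1C(C)NC(=O)N(C)S(=O)(=O)c1ccc(C)cc1`, has not yet been measured in this assay. It differs from compound 1 in one place: methyl in place of chloro on an aromatic carbon. For the measured compounds named here, no pair of measured compounds shows this same change, so there is nothing among the measured numbers to tell how large its effect is. With that in mind, the step of a 1.1-fold lower number from compound 1 to compound 4 (0.05 log units; within the scatter) is expected to be none beyond the scatter, in either direction. Compound 4 is therefore estimated at 50000 nM, with a range from 18000 nM to 140000 nM.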

Compound 4, half-maximal effective concentration: 28600 nM
Beside the measured number, compound 4's estimate is 1.7-fold (0.24 log units) above it; low and high end bracket the measured number.
By their numbers in this assay, from the lowest: compound 3; then compounds 4, 1 and 2 (each within the scatter of the next, the first and the last beyond it).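

In this assay, for the compounds shown here, the earlier compounds offered no pair differing at this position, and compounds 1 and 4 now supply the first: going from 4-chlorophenyl to 4-methylphenyl, with the rest of the molecule unchanged, gives a 1.9-fold lower number from compound 1 to compound 4 (0.29 log units; within the scatter) as the measured step. Chloro and methyl therefore cannot be told apart at this position on this read-out, although the step lies close to the edge of the usual scatter and a repeat measurement could matter. No measured property of either group bears on this result, so the data offer no explanation for it.

On these data alone, it remains open whether a quite different group at this position, such as an amine or a carboxylic acid, would produce a step beyond the scatter. This single pair also cannot show whether the same change would give a similar step on a different core.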